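This account rests on a few compounds, and the source may have more. Where it says the series, first, only, none or still open, it means among the compounds named here.

Compound 1 `CCOC(=O)c1ccc(NC(c2ccc(Cl)cc2)c2ccc3cccnc3c2O)cc1` carries no result in an assay on isolated protein for inhibition of CAAX prenyl protease 2 (Homo sapiens), with stated times of 60 s and 60 min; a lower number here means a stronger inhibitor, a higher number a weaker inhibitor: for compound 1 the entry reads "not determined" (no result reported). Compound 2 `Oc1c(C(Nc2ccccc2)c2ccccc2)ccc2ccccc12`, in this assay, gives 4900 nM; as the only number shown, it stands alone, with nothing measured to rank it against. Compound 3 `O=C(O)c1cccc(NC(c2ccccc2)c2ccc3ccccc3c2O)c1` differs from compound 2 in a single place: carboxy in place of hydrogen on an aromatic carbon. Among the compounds with values here, no step between two measured compounds is available to set the size of such a change, so the expectation for compound 3 rests on compound 2 at 4900 nM alone. Without a comparable pair, the added carboxy group is expected to shift the half-maximal inhibitory concentration by no more than the usual scatter in either direction, and the step from compound 2 to compound 3 is estimated as a 1.4-fold lower number from compound 2 to compound 3 (0.15 log units; within the scatter). Compound 3 is therefore expected to give 3500 nM in this assay, with a plausible range from 800 nM to 15000 nM.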

Compound 3, half-maximal inhibitory concentration: 5300 nM
For compound 3 the middle estimate is 1.5-fold (0.18 log units) below the measured one; measured number inside the range.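

Within the data shown here, the change from phenyl to 3-carboxyphenyl supplies the first step that can be read in this assay, a 1.1-fold higher number from compound 2 to compound 3 (0.03 log units; within the scatter). Until now, compound 2 stood alone and could not show what a substituent on this aromatic carbon would do; this step shows that carboxy, with its 3 heavy atoms and its hydrogen-bond donor and acceptor, can stand here with the two numbers remaining within the scatter of each other. No measurement shown bears on why this is so.

Going by these compounds, whether an amine, an amide or a longer chain ending in a carboxylic acid would give a similar result at this carbon remains open. So does whether carboxy on another carbon of the same ring would give the same reading.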